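Acylurea-Thiazole Hydrazones: Cytotoxicity Toward Liver Cells

The source may hold more compounds than are shown below. What is called first, only, known or untested is meant among the compounds shown, and "the series" means these compounds.

Measured compounds and values:
- compound 1, `CN(C(=O)NC(=O)c1ccc(F)c(F)c1)c1nc(C(F)(F)F)c(C(=O)N/N=C/c2ccc(C(F)(F)F)cc2)s1`: 13.2 ug/mL
- compound 2, `CN(C(=O)NC(=O)c1ccc(F)c(F)c1)c1nc(C(F)(F)F)c(C(=O)N/N=C/c2ccccc2C(F)(F)F)s1`: "not determined" (no result reported)
- compound 3, `CN(C(=O)NC(=O)c1ccc(F)c(F)c1)c1nc(C(F)(F)F)c(C(=O)N/N=C/c2cccc(C(F)(F)F)c2)s1`: 23.5 ug/mL

In an ADME assay on L02 cells (Homo sapiens) for inhibition, read by MTT assay, with a stated time of 72 h (a lower number here means a stronger inhibitor, a higher number a weaker inhibitor), compound 1 gives 13.2 ug/mL and compound 3 gives 23.5 ug/mL. For the measured compounds named here, the one step that connects two measured compounds, a 1.8-fold higher number from compound 1 to compound 3 (0.25 log units; within the scatter), stays within the scatter, so these two are read as equal. Compound 2, which carries the 2-(trifluoromethyl)phenyl hydrazone arm, has no number in this assay and so has no position on the scale shown.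

Compound 4, `CN(C(=O)NC(=O)c1ccc(C(F)(F)F)cc1)c1nc(C(F)(F)F)c(C(=O)N/N=C/c2ccccc2C(F)(F)F)s1`, arises from compound 2 by one change: 4-(trifluoromethyl)phenyl in place of 3,4-difluorophenyl on a carbonyl carbon. Going by the values given here, no measured step touches this change. Among the compounds with values here, the only step recorded concerns the other end of the molecule, the hydrazone arm, and it was within the scatter. Nothing shown supports a move beyond the scatter in either direction; the expected outcome is therefore a value of the same order as those of compound 1 and compound 3, with wide uncertainty since compound 2 itself is without a number. For compound 4 the value in this assay is estimated at 18 ug/mL, ranging from 6 ug/mL to 50 ug/mL.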

Compound 4, half-maximal inhibitory concentration: 12.4 ug/mL
Estimate against measurement, compound 4: 1.5-fold (0.16 log units) above; the measured number falls inside the stated range.
By their numbers in this assay, from the lowest: compounds 4, 1 and 3 (each within the scatter of the next).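

Compound 4 differs in one place only from compound 2, which has no number in this assay, so no step can be read from this pair. No measured evidence bears on this result. As far as these compounds go, whether 4-(trifluoromethyl)phenyl in place of 3,4-difluorophenyl on the carbonyl carbon shifts the value remains open.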